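The source may report more compounds than this note shows. Statements on the series, on what has been measured and on what is new or still open speak of the compounds shown alone.

Compounds measured in an ADME assay on MDCK cells (Canis lupus familiaris) for cytotoxicity, read by MTT assay, with a stated time of 2 days (a higher number here means that more compound is tolerated, a lower number that less compound is tolerated), so far

Compound 1 `NCCCc1ccc(-c2ccc(-c3cccs3)s2)s1` gives 18900 nM
Compound 2 `[N-]=[N+]=NCCCc1ccc(-c2ccc(-c3cccs3)s2)s1` gives > 200000 nM as a limit of the assay

Compound 2 has no number in this assay and stands only at that limit. Compound 3 `[N-]=[N+]=NCCCCc1ccc(-c2ccc(-c3cccs3)s2)s1` differs from it thus: azidomethyl in place of azido on a saturated chain carbon, three bonds along the chain from an aromatic carbon; 3-azidopropyl becomes 4-azidobutyl and the azido group stays. Among the compounds with values here, the one measured step, an at least 10-fold higher number from compound 1 to compound 2 (1.02 log units; beyond the scatter), was large, but it replaced amino with azido and does not size this change, so no step beyond the scatter is expected in either direction. The expected change is a number no higher from compound 2 to compound 3 (the limit leaves the size open) as an estimate. Compound 3 is expected near 200000 nM with an estimated range from 90000 nM to 400000 nM in this reading. A limit rather than a number may well be reported for compound 3.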

Compound 3, half-maximal cytotoxic concentration: > 200000 nM
Compound 3 gave a limit, no number (the forecaster's own chance of this, stated with the estimate: 60%); the middle value sits exactly at the limit.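

In this assay the 4-azidobutyl chain of compound 3 also gives only a limit, as the 3-azidopropyl chain of compound 2 does, so the longer chain does not bring a number into range at this place. Set against the amine, the longer azide gives an at least 10-fold higher number from compound 1 to compound 3 (1.02 log units; beyond the scatter). The step between the two azides cannot be read, because both stand at the limit: the limit of > 200000 nM in this assay, at which 2 of the 3 values shown sit.

From the compounds shown here alone, how far past that limit either azide lies stays open. So does what an amine on the 4-butyl chain would give.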